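The compounds below may be only part of what the source reports. "The series", "measured", "known", "first", "only" and "open" are said of these compounds alone.

Compound 1 `CC1(C)Cc2c(ccc(C(=O)/C=C/c3ccccc3)c2OCc2ccccc2)O1` was examined in a functional assay on B16 cells (Mus musculus) for antiproliferative activity, read by MTT assay, with a stated time of 48 h; a higher number here means a weaker inhibitor, a lower number a stronger inhibitor. In this assay compound 1 gives only a limit of the assay, > 100000 nM. Compound 2 `CC1(C)Cc2c(ccc(C(=O)/C=C/c3ccc(F)cc3)c2OCc2ccccc2)O1` carries fluoro in place of hydrogen on an aromatic carbon. In this assay compound 2 likewise stands only at a limit, > 100000 nM. Among the compounds with values here, the one measured step, a step that the two limits leave unreadable from compound 1 to compound 2, thus offers no number. Both values sit at the limit of > 100000 nM in this assay, at which 2 of the 2 values shown sit. Compound 3 `COc1ccc(/C=C/C(=O)c2ccc3c(c2OCc2ccccc2)CC(C)(C)O3)cc1` differs from compound 2 by methoxy in place of fluoro on an aromatic carbon. Within the data shown here, the single measured step bears on this change only in showing no readable size, so no direction and no magnitude can be drawn from it for this assay . Compound 3 is therefore expected to remain at the limit as well, with a step that the limit leaves unreadable from compound 2 to compound 3 expected to lie within the scatter. The estimate for compound 3 in this assay is 150000 nM, within 50000 nM to 500000 nM.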

Compound 3, half-maximal inhibitory concentration: > 100000 nM
Compound 3: no number, only a limit; the forecaster's own chance of this, stated with the estimate: 75%; the middle value lies beyond the limit too.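

In this assay compound 3 gives only a limit, > 100000 nM. No step among compound 1, compound 2 and compound 3 can be read: the limit of > 100000 nM in this assay, at which 3 of the 3 values shown sit.

The compounds shown leave open whether hydrogen, fluoro and methoxy at this place differ at all in this read-out.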